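Swapping bromo for methoxy with one measured anchor

This account rests on a few compounds, and the source may have more. Where it says the series, first, only, none or still open, it means among the compounds named here.

Measured so far in a functional assay on A375-C5 cells (Homo sapiens) for inhibition, read by sulforhodamine B assay, with a stated time of 48 h; a higher number here means a weaker inhibitor of growth, a lower number a stronger inhibitor of growth:
- compound 1 `O=C(/C=C/c1ccc(Br)cc1)c1ccc(O)cc1O` - "not determined" (no result reported)
- compound 2 `CCCc1c(O)ccc(C(=O)/C=C/c2ccc(OCOC)cc2OCOC)c1O` - 35000 nM
- compound 3 `CCCc1c(O)ccc(C(=O)/C=C/c2ccc(Br)cc2)c1O` - "not determined" (no result reported)

For the measured compounds named here, only one of these three compounds has yielded a number, which makes for a thin starting point. Compound 3 has no value to stand on, since its entry reads "not determined" (no result reported). Compound 1 has the same gap, so neither can be ranked against the other or against compound 2.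

The next compound to be tested is compound 4 `CCCc1c(O)ccc(C(=O)/C=C/c2ccc(OC)cc2)c1O`, which is made from compound 3 by a single change: methoxy in place of bromo on an aromatic carbon. Put simply, methoxy takes the place of bromo on an aromatic carbon, para to a large group.

Going by the values given here, no measured pair shows what this kind of swap does in this assay, so the data offer neither a size nor a direction for it. Among the compounds with values here, the working expectation is therefore a value no further from the only available number than the usual scatter, with no favoured direction. Within the data shown here, that number is the one for compound 2 at 35000 nM, and it anchors the estimate, though loosely, so the range is kept wide. Compound 4 is expected at about 30000 nM, with an estimated range from 10000 nM to 80000 nM.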

Compound 4, concentration for 50% growth inhibition: 46300 nM
Compound 4: middle estimate off by 1.5-fold (0.19 log units), on the low side; the range from low to high includes it.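

In this assay, for the compounds shown here, compound 4 gives 46300 nM while compound 3 gives "not determined" (no result reported) and so no step from bromo to methoxy can be read from this pair. The compounds shown leave open whether this swap strengthens or weakens growth inhibition, and by how much. No measurement shown here offers a reason for the value of compound 4.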